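Carbamate ester variation in the aryl selenocyanate series

The source may hold more compounds than are shown below. What is called first, only, known or untested is meant among the compounds shown, and "the series" means these compounds.

Measured compounds in a functional assay on MCF7 cells (Homo sapiens) for cytotoxicity, read by MTT assay, with a stated time of 72 h; a lower number here means a stronger inhibitor of growth, a higher number a weaker inhibitor of growth:
compound 1, `CCCOC(=O)Nc1ccc([Se]C#N)cc1`, 34400 nM
compound 2, `N#C[Se]c1ccc(NC(=O)Oc2ccccc2)cc1`, 35900 nM
compound 3, `N#C[Se]c1ccc(NC(=O)Oc2ccc(Cl)cc2)cc1`, 26300 nM

Of the three numbers, compound 2 has the highest, but the gaps are small: the step of a 1.0-fold higher number from compound 1 to compound 2 (0.02 log units; within the scatter) and the step of a 1.4-fold lower number from compound 2 to compound 3 (0.14 log units; within the scatter) both sit inside the scatter, and compounds 1 and 3 differ from each other by no more than that either. On these numbers the three carbamates are not separated.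

Compound 4, `CCCCOC(=O)Nc1ccc([Se]C#N)cc1`, is the next member to be measured. Its change from compound 2 is butyl in place of phenyl on an oxygen next to a carbonyl group. The step that bears on it most directly is a 1.0-fold higher number from compound 1 to compound 2 (0.02 log units; within the scatter), which exchanged propyl for phenyl at the same oxygen next to a carbonyl group and moved the number by an amount within the scatter. Butyl differs from propyl by a single carbon of chain, so the reverse exchange, from phenyl to butyl, is expected to move the number no more than the scatter in either direction.

Compound 4 is therefore expected to give about 33000 nM in this assay, with a range of 18000 nM to 60000 nM, which amounts to an expected step of a 1.1-fold lower number from compound 2 to compound 4 (0.04 log units; within the scatter).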

Compound 4, concentration for total growth inhibition in the MCF7 assay: 20200 nM
Compound 4: middle estimate off by 1.6-fold (0.21 log units), on the high side, and the stated range covers the measured number.
By their numbers in the MCF7 assay, from the lowest: compounds 4, 3, 1 and 2 (each within the scatter of the next).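

In the MCF7 assay the steps of a 1.8-fold lower number from compound 2 to compound 4 (0.25 log units; within the scatter) and a 1.7-fold lower number from compound 1 to compound 4 (0.23 log units; within the scatter) leave compound 4 level with both neighbours, so neither butyl for phenyl nor the extra chain carbon separates these carbamates in this read-out. In a physicochemical assay, with a stated time of 6 min, tested at 0.1 mg/mL (a higher number here means more inhibition at the concentration tested (going by the name of the read-out), a lower number less inhibition), compound 2 gives > 25% as a limit of the assay and not a number: the limit of > 25% in the physicochemical assay, at which 1 of the 2 values shown sits.
In the physicochemical assay compound 4 gives 12.6% and the step reads a number at least 12.4 percentage points lower from compound 2 to compound 4 (beyond the scatter) so that butyl for phenyl on this oxygen gives the first difference beyond the scatter in the series, with its full size unknown.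

As far as these compounds go, whether a longer chain such as hexyl, or a benzyl group, on this oxygen would separate from compound 4 in the MCF7 assay stays open. Also open, from the compounds shown here alone, is whether any change at this oxygen can move both read-outs together.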